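Swapping a Cyclobutyl for a Methylthiophene on the Core

A few compounds are considered here, and "the series" means these few. Any claim that something is new, unique, unknown or untested is made for them only; others in the source may bear on it.

Of the compounds shown here, two have been measured so far, compound 1 `COc1cccc(Cn2nnc(-c3ccccc3)c2C(=O)N[C@@H](C)c2ccc(C(=O)O)cc2)c1` and compound 2 `C[C@H](NC(=O)c1c(C2CCC2)nnn1Cc1ccc(C(F)(F)F)cc1)c1ccc(C(=O)O)cc1`, which share the same core. In a functional assay on CHO cells for antagonist activity at prostaglandin E2 receptor EP4 subtype (Homo sapiens), read by calcium flux, with a stated time of 15 min (on this read-out higher numbers stand for weaker inhibition and lower numbers for stronger inhibition), compound 1 gives 96.8 nM, and in this assay compound 2 gives 75.3 nM. Compound 2 holds the lower of the two numbers, but its gap to compound 1 lies within the usual scatter, so the two cannot be told apart.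

Compound 3 `Cc1ccc(-c2nnn(Cc3ccc(C(F)(F)F)cc3)c2C(=O)N[C@@H](C)c2ccc(C(=O)O)cc2)s1` has not yet been measured. It differs from compound 2 in a single place: 5-methylthiophen-2-yl in place of cyclobutyl on an aromatic carbon. Going by the values given here, no measured pair shows this kind of exchange, so the expectation rests on the two numbers alone, and compound 1, which also carries an aromatic ring where compound 2 carries cyclobutyl, stands close to compound 2. The expected step from compound 2 to compound 3 in this assay is a 1.2-fold lower number from compound 2 to compound 3 (0.06 log units; within the scatter), nothing beyond the scatter. Compound 3 is therefore estimated at 65 nM, with a range from 22 nM to 190 nM.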

Compound 3, half-maximal inhibitory concentration: 4.6 nM
Compound 3: middle estimate off by 14-fold (1.15 log units), on the high side; measured number below the stated range.
By their numbers in this assay, from the lowest: compound 3; then compounds 2 and 1 (each within the scatter of the next).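

In this assay the group on this aromatic carbon turns out to matter a great deal: 5-methylthiophen-2-yl in place of cyclobutyl brings a 16-fold lower number from compound 2 to compound 3 (1.21 log units; beyond the scatter) and this step lies well beyond the scatter. Compound 1 and compound 2 differ in more than one place, so they could not show how strongly this one position responds to the group it carries. Nothing available here accounts for the size of the step.

Still open, going by these compounds, is which part of the entering group matters, the sulfur-containing aromatic ring or its methyl: an unsubstituted thiophen-2-yl group or a 5-methylfuran-2-yl group at this position would help separate the two. Also open, on these data alone, is whether the same exchange would have a similar effect with a group other than 4-(trifluoromethyl)benzyl on the shared core.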